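This account rests on a few compounds, and the source may have more. Where it says the series, first, only, none or still open, it means among the compounds named here.

Compound 1 `O=C(CSc1nc(Nc2ccccc2)c2ccccc2n1)Nc1cccc(F)c1`: 15600 nM
Compound 2 `O=C(CSc1nc(Nc2ccccc2)c2ccccc2n1)Nc1ccc(Cl)cc1`: 12900 nM
Compound 3 `C=CC(=O)Nc1cccc(NC(=O)CSc2nc(Nc3cccc(F)c3)c3ccccc3n2)c1`: 5370 nM

In a functional assay on PC-3 cells (Homo sapiens) for inhibition, read by MTT assay, with a stated time of 72 h (a lower number here means a stronger inhibitor, a higher number a weaker inhibitor), compound 3 gives the lowest of the three numbers; compound 2 and compound 1 both give higher numbers, each beyond the scatter. Compound 4 `C=CC(=O)Nc1cccc(NC(=O)CSc2nc(Nc3ccc(Cl)c(Cl)c3)c3ccccc3n2)c1` differs from compound 3 by 3,4-dichlorophenyl in place of 3-fluorophenyl on a nitrogen on an aromatic ring. Among the compounds with values here, the one measured step that bears on this is a halogen swap on a different nitrogen, a 1.2-fold lower number from compound 1 to compound 2 (0.08 log units; within the scatter), which lies within the scatter. Within the data shown here, no measured pair tests a halogen swap on the nitrogen on the aromatic ring, so that bearing is indirect. The step of a 1.2-fold lower number from compound 3 to compound 4 (0.08 log units; within the scatter) is therefore expected to be small, most likely within the scatter, in either direction. Compound 4 is estimated at 4500 nM, with a range from 2000 nM to 10000 nM.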

Compound 4, half-maximal inhibitory concentration: 27600 nM
Beside the measured number, compound 4's estimate is 6.1-fold (0.79 log units) below it; the whole stated range lies below it.
By their numbers in this assay, from the lowest: compound 3; then compounds 2, 1 and 4 (each within the scatter of the next, the first and the last beyond it).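

In this assay the nitrogen on an aromatic ring responds to its aryl group: 3,4-dichlorophenyl in place of 3-fluorophenyl gives a 5.1-fold higher number from compound 3 to compound 4 (0.71 log units; beyond the scatter). The halogen change on the amide-type nitrogen, by contrast, gives only a 1.2-fold lower number from compound 1 to compound 2 (0.08 log units; within the scatter). Nothing available explains the larger step at this position.

Open, going by these compounds, is whether the step follows the chlorines, their number, or the loss of fluorine. Also open, on these data alone, is how this nitrogen tolerates a phenyl carrying an amine or a carboxylic acid.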